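Vinyl in Place of Methoxy: Expecting Another Limit

The source may hold more compounds than are shown below. What is called first, only, known or untested is meant among the compounds shown, and "the series" means these compounds.

Compound 1 `C/C(=C\c1cc(-c2ccc(S(C)(=O)=O)cc2)cs1)C(N)=O` gives > 50000 nM in a functional assay on BGC-823 cells (Homo sapiens) for cytotoxicity, read by CCK-8 assay, with a stated time of 24 h; a lower number here means a stronger inhibitor, a higher number a weaker inhibitor.
Compound 2 `COc1ccc(-c2csc(/C=C(\C)C(N)=O)c2)cc1` gives > 50000 nM in this assay.

Both values are limits of the assay, not numbers. The step that the two limits leave unreadable from compound 1 to compound 2 cannot be read because the limit of > 50000 nM in this assay, at which 2 of the 2 values shown sit, covers both ends of it. Compound 3 `C=Cc1ccc(-c2csc(/C=C(\C)C(N)=O)c2)cc1` differs from compound 2 by vinyl in place of methoxy on an aromatic carbon. Going by the values given here, no readable measured step bears on this change; the only neighbouring step is the unreadable one. Compound 3 is therefore expected at about 60000 nM, with a range from 15000 nM to 250000 nM, most likely reported again only as a limit. The expected step that the limit leaves unreadable from compound 2 to compound 3 amounts to nothing beyond the scatter.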

Compound 3, half-maximal inhibitory concentration: > 50000 nM
Compound 3 was reported as a limit; the forecaster's own chance of this, stated with the estimate: 85%; the middle value lies beyond the limit too.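

No step can be read among compound 1, compound 2 and compound 3, because each value is a limit and not a number: the limit of > 50000 nM in this assay, at which 3 of the 3 values shown sit.

The compounds shown leave open how methylsulfonyl, methoxy and vinyl compare in this assay.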